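Swapping the halogen pattern on a benzyl triazole dithiocarbamate

The source may hold more compounds than are shown below. What is called first, only, known or untested is meant among the compounds shown, and "the series" means these compounds.

Measured so far:
compound 1 `O=C(OCc1ccccc1)N1CCN(C(=S)SCc2cn(Cc3ccc(F)cc3)nn2)CC1`: 10300 nM
compound 2 `COc1cc(Cn2cc(CSC(=S)N3CCNCC3)nn2)cc(OC)c1OC`: "not determined" (no result reported)

Within the data shown here, compound 1 gives the only number here. In a functional assay on MCF7 cells (Homo sapiens) for inhibition, read by MTT assay, with a stated time of 72 h (on this read-out higher numbers stand for weaker inhibition and lower numbers for stronger inhibition), compound 1 gives 10300 nM, while for compound 2 the entry reads "not determined" (no result reported). Compound 3 `O=C(OCc1ccccc1)N1CCN(C(=S)SCc2cn(Cc3ccc(Cl)c(Cl)c3)nn2)CC1` has not been measured. It differs from compound 1 by 3,4-dichlorophenyl in place of 4-fluorophenyl on a saturated chain carbon bound to an aromatic nitrogen. Among the measured compounds shown here, no measured pair shows a comparable change, so there is nothing to lean on beyond the structures themselves. The expected step of a 1.7-fold lower number from compound 1 to compound 3 (0.23 log units; within the scatter) is a modest gain in inhibition, near the edge of the usual scatter. Compound 3 is therefore estimated at 6000 nM, between 2000 nM and 20000 nM.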

Compound 3, half-maximal inhibitory concentration: 10600 nM
Beside the measured number, compound 3's estimate is 1.8-fold (0.25 log units) below it, within the range that was stated.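

In this assay, the change from 4-fluorobenzyl to 3,4-dichlorobenzyl gives a 1.0-fold higher number from compound 1 to compound 3 (0.01 log units; within the scatter) and so leaves the read-out unchanged within the usual scatter. Among these compounds, this is the first measured pair, and it shows that this particular halogen swap at this position does not separate the two compounds. Nothing measured here gives a reason for this result.

The compounds shown leave open whether this position stays as insensitive to groups of a different kind. A benzyl carrying an amine or a carboxylic acid, or a longer chain in place of the benzyl group, could give a clearer answer.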